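A few compounds are considered here, and "the series" means these few. Any claim that something is new, unique, unknown or untested is made for them only; others in the source may bear on it.

Measured compounds in a functional assay on HepG2 cells (Homo sapiens) for cytotoxicity, read by MTT assay, with a stated time of 48 h; a higher number here means a weaker inhibitor, a lower number a stronger inhibitor:
- compound 1, `Cc1nnc(SCC(=O)c2ccccc2)n1N1C(=O)c2ccccc2C1=O`: compound 1 reaches only the assay limit, > 200000 nM
- compound 2, `C=CCSc1nnc(CC)n1N1C(=O)c2ccccc2C1=O`: compound 2 reaches only the assay limit, > 200000 nM
- compound 3, `CCc1nnc(SCc2ccccc2)n1N1C(=O)c2ccccc2C1=O`: compound 3 reaches only the assay limit, > 200000 nM

Compound 3 therefore has no number in this assay, only a limit, and the same holds for the two other measured values, all three sitting at the limit of > 200000 nM in this assay, at which 3 of the 3 values shown sit. Among the measured compounds shown here, the one step between measured compounds, a step that the two limits leave unreadable from compound 2 to compound 3, is not readable, since both ends are limits.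

Compound 4, `CCc1nnc(SCC(=O)c2ccccc2)n1N1C(=O)c2ccccc2C1=O`, differs from compound 3 by benzoyl in place of phenyl on a saturated chain carbon bound to a sulfur. For the measured compounds named here, no measured step bears on this change. Compound 1 carries the same benzoylmethyl group on sulfur with a methyl instead of an ethyl on the core, and it too sits at the limit, so the shown values give no sign that a benzoylmethyl group on sulfur brings the series off the limit.

The expectation for compound 4 in this assay is therefore no readable step, a step that the limit leaves unreadable from compound 3 to compound 4, with compound 4 most likely again reported only as a limit. Compound 4 is estimated at 300000 nM, in a range from 100000 nM to 1000000 nM.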

Compound 4, half-maximal inhibitory concentration: > 200000 nM
Compound 4: a limit, no number; the forecaster's own chance of this, stated with the estimate: 85%; the middle value lies beyond the limit too.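

In this assay compound 4 gives > 200000 nM, a limit and not a number. No step from compound 1, compound 2 or compound 3 to compound 4 can be read, because every end of these steps is a limit: the limit of > 200000 nM in this assay, at which 4 of the 4 values shown sit.

The compounds shown leave open how these four rank against one another in this assay, and whether any change on sulfur or on the core gives a readable value.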